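This account rests on a few compounds, and the source may have more. Where it says the series, first, only, none or still open, it means among the compounds named here.

Measured so far:
- compound 1, `COc1ccccc1C(=O)c1sc(Nc2ccccc2)nc1N`: 1300 nM
- compound 2, `Nc1nc(Nc2ccc(F)cc2)sc1C(=O)c1ccccc1`: > 10000 nM
- compound 3, `COc1ccc(C(=O)c2sc(Nc3ccc(F)cc3)nc2N)cc1`: > 10000 nM

All three were tested in a functional assay on MOLT-4 cells (Homo sapiens) for antiproliferative activity, read by cell counting, with a stated time of 2 days; a higher number here means a weaker inhibitor, a lower number a stronger inhibitor. In this assay, going by the values given here, compound 1 gives 1300 nM, the only value in the set that is a number. For compound 2 the assay reports only a limit, > 10000 nM. For compound 3 it likewise reports only a limit, > 10000 nM. Compound 1 and compound 2 differ in more than one place, and the difference between the two cores is not broken down here.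

Compound 2 and compound 3 differ by a single change, (methoxy in place of hydrogen on an aromatic carbon). The step that the two limits leave unreadable from compound 2 to compound 3 cannot be read, because the limit of > 10000 nM in this assay, at which 2 of the 3 values shown sit, means neither end of the step is a number.

Compound 4, `COc1ccc(Nc2nc(N)c(C(=O)c3ccccc3OC)s2)cc1`, is not yet measured. Among the compounds with values here, it differs from compound 1 by methoxy in place of hydrogen on an aromatic carbon, the same change as the one from compound 2 to compound 3. Since that earlier step gave no readable size, the expectation for compound 4 rests on compound 1 alone, whose value in this assay is 1300 nM. With no measured guide to the direction of the change, compound 4 is expected to land near its parent, which means an expected step of a 1.2-fold higher number from compound 1 to compound 4 (0.06 log units; within the scatter). Compound 4 is therefore estimated at 1500 nM, with a wide range from 400 nM to 6000 nM.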

Compound 4, half-maximal inhibitory concentration: 18 nM
The estimate for compound 4 lay 83-fold (1.92 log units) above the measured number; measured number below the stated range.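

In this assay, swapping phenyl for 4-methoxyphenyl on the core of compound 1 gives a 72-fold lower number from compound 1 to compound 4 (1.86 log units; beyond the scatter) and so turns a modest inhibitor into a much stronger one. This is a single step on a single core, so it shows that the change can matter greatly in this series, but not that it will help on another core or that the gain can be expected wherever the methoxy is placed. The only other example of this change, from compound 2 to compound 3, cannot be read and therefore neither supports nor contradicts the result for compound 4, because both of its ends are limits rather than numbers: the limit of > 10000 nM in this assay, at which 2 of the 4 values shown sit.

The compounds shown leave open whether the large gain depends on methoxy itself, since no compound here carries a hydroxyl, an amine or a longer chain such as ethoxy in its place. They also leave open how much the gain relies on the rest of the core of compound 1, and a second readable pair with numbers at both ends would be needed to test whether the change carries across cores.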